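Ester chain variation in a cinnamate series against pak choi

This account rests on a few compounds, and the source may have more. Where it says the series, first, only, none or still open, it means among the compounds named here.

Measured compounds:
Compound 1 `CC(C)=CCCC(C)CCOC(=O)/C=C/c1ccc(C(C)C)cc1`: 39%
Compound 2 `CC(C)c1ccc(/C=C/C(=O)OCCc2ccccc2)cc1`: 36%
Compound 3 `CCCCCOC(=O)/C=C/c1ccc(C(C)C)cc1`: 29%

In a functional assay on the whole organism for inhibition, with Brassica rapa subsp. chinensis as the target, with a stated time of 3 days, tested at 100 ppm (a higher number here means more inhibition of growth at the concentration tested, a lower number less inhibition of growth), compound 1 gives 39%, compound 2 gives 36% and compound 3 gives 29%. Compound 3 stands lowest of the three numbers, but its distance to compound 2, a number 7 percentage points lower from compound 2 to compound 3 (within the scatter), and to compound 1, a number 10 percentage points lower from compound 1 to compound 3 (within the scatter), both lie within the scatter, so no order among the three can be read from them.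

Compound 4 `CCOC(=O)/C=C/c1ccc(C(C)C)cc1` differs from compound 3 by hydrogen in place of propyl on a saturated chain carbon, two bonds along the chain from an oxygen next to a carbonyl group. All three measured steps alter the same place in the chain: a number 3 percentage points lower from compound 1 to compound 2 (within the scatter), a number 10 percentage points lower from compound 1 to compound 3 (within the scatter) and a number 7 percentage points lower from compound 2 to compound 3 (within the scatter), each within the scatter. Changes at this place have so far produced no step beyond the scatter, so for compound 4 no step beyond the scatter is expected in this assay either; the direction, if any, is downward in line with the measured trend, which rests only on these three compounds.

For compound 4 the expected value in this assay is 25%, estimated range 10% to 40%, meaning an expected step of a number 4 percentage points lower from compound 3 to compound 4 (within the scatter).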

Compound 4, percent growth inhibition at one concentration: 44%
Estimate against measurement, compound 4: 19 percentage points below; measured number above the stated range.
By their numbers in this assay, from the lowest: compounds 3, 2, 1 and 4 (each within the scatter of the next, the first and the last beyond it).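

In this assay, going by these compounds alone, going from the pentyl to the ethyl ester gives the first step beyond the scatter at this position, a number 15 percentage points higher from compound 3 to compound 4 (beyond the scatter), so changes here can register in this read-out. The other two steps, a number 8 percentage points higher from compound 2 to compound 4 (within the scatter) and a number 5 percentage points higher from compound 1 to compound 4 (within the scatter), lie within the scatter, so the ethyl ester separates only from the pentyl ester and no steady trend with the size of the chain can be read across the four compounds. Nothing available bears on why the pentyl and ethyl esters differ.

Open, on these data alone, is whether the separation holds for a methyl ester or a butyl ester, which would show if it follows chain length. Also open, as far as these compounds go, is how a terminal amine or carboxylic acid on the ester chain would read here.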